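CXCR4 antagonist series: benzylic amine side-chain swap

A few compounds are considered here, and "the series" means these few. Any claim that something is new, unique, unknown or untested is made for them only; others in the source may bear on it.

Measured so far:
compound 1, `c1ccc(CN(CCCCN(C[C@H]2Cc3ccccc3CN2)[C@H]2CCCc3cccnc32)Cc2ccccn2)nc1`, 664 nM
compound 2, `c1ccc2c(c1)CN[C@@H](CN(CCCCNCC1CCNCC1)[C@H]1CCCc3cccnc31)C2`, 36.5 nM
compound 3, `c1ccc2c(c1)CN[C@@H](CN(Cc1ccc(CNCc3ccncc3)cc1)[C@H]1CCCc3cccnc31)C2`, 134 nM

All three share a core and were tested in a functional assay on cells for antagonist activity at C-X-C chemokine receptor type 4 (Homo sapiens), read by fluorescence and calcium flux, with stated times of 25 min and 90 s; on this read-out higher numbers stand for weaker inhibition and lower numbers for stronger inhibition. Compound 2 gives the lowest number of the three; its gaps to compound 3 and to compound 1 both lie beyond the scatter, so compound 2 is the strongest inhibitor among the measured compounds. Compound 1, which carries two pyridinylmethyl groups on its chain nitrogens, gives the weakest number in this assay.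

Compound 4, `C(=C/CN(C[C@H]1Cc2ccccc2CN1)[C@H]1CCCc2cccnc21)\CNCc1ccccn1`, has not been measured. It differs from compound 2 by a group of 11 heavy atoms (9 carbon, 2 nitrogen; one six-membered aromatic ring with 1 hetero atom) in place of a group of 11 heavy atoms (9 carbon, 2 nitrogen; one six-membered non-aromatic ring with 1 hetero atom), on a saturated chain carbon bound to an amine nitrogen.

The new group brings compound 4 closer in make-up to compound 1, whose value of 664 nM is the weakest measured. Compound 4 is therefore expected to inhibit less strongly than compound 2; the step of a 6.0-fold higher number from compound 2 to compound 4 (0.78 log units; beyond the scatter) is estimated to go upward and beyond the scatter. For compound 4 an estimate of 220 nM is made, within a range from 60 nM to 800 nM.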

Compound 4, half-maximal inhibitory concentration: 58.3 nM
Beside the measured number, compound 4's estimate is 3.8-fold (0.58 log units) above it, outside the stated range (below it).
By their numbers in this assay, from the lowest: compounds 2 and 4 (each within the scatter of the next); then compound 3; then compound 1.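

In this assay the exchange on a saturated chain carbon bound to an amine nitrogen gives a 1.6-fold higher number from compound 2 to compound 4 (0.20 log units; within the scatter) and so does not separate the two compounds. Among the compounds shown here, this is the first pair that differs in one place, and it shows that the six-membered aromatic ring with 1 hetero atom, with its double bond outside aromatic rings, can stand in place of the six-membered non-aromatic ring with 1 hetero atom without a step beyond the scatter. No supporting measurement bears on why the two compounds read alike.

The ring and the double bond enter together, so the compounds shown do not separate their contributions. Going by these compounds, how a carboxylic acid or a longer chain at this place would read in this assay stays open.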